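A few compounds are considered here, and "the series" means these few. Any claim that something is new, unique, unknown or untested is made for them only; others in the source may bear on it.

Measured so far in an assay on LtK cells with ATP-sensitive inward rectifier potassium channel 11 (Homo sapiens) as the target; a lower number here means that less compound is needed, a higher number that more compound is needed for the effect:
compound 1, `CC(C)CCC(=O)Nc1c(C(O)(C(F)(F)F)C(F)(F)F)ccc2ccccc12`, gives 49 nM
compound 2, `Cc1ccccc1C(=O)Nc1c(C(O)(C(F)(F)F)C(F)(F)F)ccc2ccccc12`, gives 5550 nM
compound 3, `N#Cc1cccc(C(=O)Nc2c(C(O)(C(F)(F)F)C(F)(F)F)ccc3ccccc23)c1`, gives 12 nM

All three share one core and differ only in the group on the carbonyl carbon of the amide. Compound 3, carrying a 3-cyanophenyl there, stands at the lowest number of the three in this assay: one measured step is a 4.1-fold lower number from compound 1 to compound 3 (0.61 log units; beyond the scatter), the other is a 460-fold lower number from compound 2 to compound 3 (2.67 log units; beyond the scatter), both beyond the scatter.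

Compound 4, `O=C(Nc1c(C(O)(C(F)(F)F)C(F)(F)F)ccc2ccccc12)c1cccc([N+](=O)[O-])c1`, keeps the 3-cyanophenyl scaffold of compound 3 but swaps the substituent on it: nitro in place of cyano on an aromatic carbon.

Among the compounds with values here, none of the measured steps swaps one small substituent on the phenyl for another; the steps to compound 3 exchange the whole group. Still, a 460-fold lower number from compound 2 to compound 3 (2.67 log units; beyond the scatter) shows that what sits on the phenyl, and where, can move the number a great deal, while a 4.1-fold lower number from compound 1 to compound 3 (0.61 log units; beyond the scatter) shows the aryl amides of this kind sit at the low end. A modest step in this assay is therefore expected, with no firm direction, and staying near compound 3 is the likeliest outcome. Compound 4 is estimated at 20 nM, with a range from 6 nM to 70 nM. That estimate means a step of a 1.7-fold higher number from compound 3 to compound 4 (0.22 log units; within the scatter).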

Compound 4, half-maximal effective concentration: 117 nM
Beside the measured number, compound 4's estimate is 5.9-fold (0.77 log units) below it, and the stated range ends below it.
By their numbers in this assay, from the lowest: compound 3; then compound 1; then compound 4; then compound 2.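

In this assay, within the data shown here, this is the first exchange of one substituent for another on the same phenyl at the same place, and a 9.8-fold higher number from compound 3 to compound 4 (0.99 log units; beyond the scatter) shows that the identity of that group matters even when nothing else in the molecule changes. With a 2.4-fold higher number from compound 1 to compound 4 (0.38 log units; beyond the scatter) the order of aryl and chain amides also turns around, since compound 3 has the lower number against the isopentyl amide compound 1 and compound 4 the higher, so an aryl amide is not at the low end as such; the 3-nitrophenyl group still stays far from the 2-methylphenyl group, with a 47-fold lower number from compound 2 to compound 4 (1.68 log units; beyond the scatter) in this assay. No measurement shown here bears on why the nitrile and the nitro group differ in this way.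

From the compounds shown here alone, whether other groups at this place, such as an amine, a carboxylic acid or a methoxy group, would fall nearer compound 3 or nearer compound 4 stays open. So does whether nitro in place of cyano would bring a step of similar size on any other aryl amide of the shared core.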